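Moving away from the carbamoyl group of compound 3

A few compounds are considered here, and "the series" means these few. Any claim that something is new, unique, unknown or untested is made for them only; others in the source may bear on it.

Among the compounds with values here, in an ADME assay on LLC-MK2 cells (Macaca mulatta) for cytotoxicity, read by spectrophotometry and crystal violet staining, with a stated time of 4 days (on this read-out lower numbers stand for higher toxicity in this test and higher numbers for lower toxicity in this test), compound 3 (`CC(C)n1ncc2c(C(=O)Nc3cc(C(N)=O)ccc3F)cc(-c3cccs3)nc21`) gives 25000 nM, the lowest of the numbers measured so far. Compound 1 (`CC(C)n1ncc2c(C(=O)Nc3ncccn3)cc(-c3cccs3)nc21`) gives 75000 nM. Compound 2 (`CC(C)n1ncc2c(C(=O)Nc3ccc(F)c(F)c3)cc(-c3cccs3)nc21`) reads > 200000 nM, which is a limit of the assay. Compound 4 (`CC(C)n1ncc2c(C(=O)Nc3ccc(F)cn3)cc(-c3cccs3)nc21`) differs from compound 3 in one place: 5-fluoropyridin-2-yl in place of 5-carbamoyl-2-fluorophenyl on an amide-type nitrogen. Two measured steps change the same substituent, a 3.0-fold lower number from compound 1 to compound 3 (0.48 log units; beyond the scatter) and an at least 8.0-fold lower number from compound 2 to compound 3 (0.90 log units; beyond the scatter), the second resting on a limit (the limit of > 200000 nM in this assay, at which 1 of the 3 values shown sits). In both, the number falls on reaching compound 3, so a rise is expected on leaving its 5-carbamoyl-2-fluorophenyl group. The expected step is a 4.0-fold higher number from compound 3 to compound 4 (0.60 log units; beyond the scatter), of modest size. For compound 4, the estimated value is 100000 nM, with an expected range of 40000 nM to 200000 nM.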

Compound 4, half-maximal cytotoxic concentration: > 200000 nM
Compound 4: a limit, no number; the forecaster's own chance of this, stated with the estimate: 30%; middle value at least 2.0-fold (0.30 log units) from the limit.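

In this assay, 5-fluoropyridin-2-yl on the amide-type nitrogen gives an at least 8.0-fold higher number from compound 3 to compound 4 (0.90 log units; beyond the scatter) and an at least 2.6-fold higher number from compound 1 to compound 4 (0.42 log units; beyond the scatter). The ring there therefore need not be of carbon only for the reading to reach the limit of the assay, although pyrimidin-2-yl in compound 1 stays lower. The step between compound 2 and compound 4 cannot be read: the limit of > 200000 nM in this assay, at which 2 of the 4 values shown sit.

Going by these compounds, whether an amine or a carboxylic acid in place of the carbamoyl group of compound 3 would also lower the number stays open. So does the true size of the readings of compound 2 and compound 4.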